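The compounds below may be only part of what the source reports. "The series", "measured", "known", "first", "only" and "open" are said of these compounds alone.

Measured so far:
Compound 1 `COc1ccc(C(c2ccc(OC(C)CN(C)C)cc2)c2cccc3ccccc23)c(OC)c1OC` — in a functional assay on THP-1 cells (Homo sapiens) for inhibition, read by sulforhodamine B assay, with a stated time of 48 h (on this read-out higher numbers stand for weaker inhibition and lower numbers for stronger inhibition), compound 1 gives 15000 nM.
Compound 2 `COc1ccc(C(OCc2ccccc2)c2cccc3ccccc23)c(OC)c1OC` — compound 2 reaches only the limit of > 20000 nM in this assay.
Compound 3 `C=CCOC(c1ccc(OC)c(OC)c1OC)c1cccc2ccccc12` — compound 3 likewise reaches only the limit of > 20000 nM in this assay.

Compound 3 thus stands at the weak end of the series, where only a limit and no number is known, and it shares that position with compound 2, as the limit of > 20000 nM in this assay, at which 2 of the 3 values shown sit, shows. For the measured compounds named here, the one measured step, a step that the two limits leave unreadable from compound 2 to compound 3, runs between two limits and is therefore unreadable.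

Compound 4 `COc1ccc(C(c2ccc(O)cc2)c2cccc3ccccc23)c(OC)c1OC` differs from compound 3 by 4-hydroxyphenyl in place of allyloxy on a saturated chain carbon bound to two aromatic carbons. Going by the values given here, no measured step bears directly on this change. Compound 1 carries a related 4-substituted phenyl and gives 15000 nM, so compound 4 is expected to sit in the same weak region. Compound 4 is estimated at 20000 nM, with a range from 6000 nM to 60000 nM. Against the limit of compound 3, the expected step of a number no higher from compound 3 to compound 4 (the limit leaves the size open) cannot be read as a gain or a loss.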

Compound 4, half-maximal inhibitory concentration: 9450 nM
Beside the measured number, compound 4's estimate is 2.1-fold (0.33 log units) above it, and the stated range covers the measured number.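

At the saturated chain carbon bound to two aromatic carbons, 4-hydroxyphenyl gives a clear gain over the ether groups, with an at least 2.1-fold lower number from compound 3 to compound 4 (0.32 log units; beyond the scatter) and an at least 2.1-fold lower number from compound 2 to compound 4 (0.32 log units; beyond the scatter) in this series. Going by these compounds, both steps start from a limit, so their full size stays unknown: the limit of > 20000 nM in this assay, at which 2 of the 4 values shown sit. On the oxygen on an aromatic ring, a 1.6-fold lower number from compound 1 to compound 4 (0.20 log units; within the scatter) shows that hydrogen and 1-((dimethylamino)methyl)ethyl cannot be told apart here. On these data alone, whether a carboxylic acid or a fluorine in place of the hydroxy group of the 4-hydroxyphenyl would strengthen inhibition remains open.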